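The compounds below may be only part of what the source reports. "The series", "measured", "known", "first", "only" and "open" are said of these compounds alone.

Measured so far:
- compound 1, `CCN(Cc1ccccc1)C(=O)COc1ccc(C)cc1`: 1880 nM
- compound 2, `COCCN(Cc1cccs1)C(=O)COc1ccc(C)cc1`: 400 nM
- compound 3, `CCN(Cc1cccs1)C(=O)COc1cccc(C)c1`: 97 nM

Of the compounds shown here, three sharing a core have been measured in an assay on HEK293 cells for agonist activity at transient receptor potential cation channel subfamily M member 8 (Homo sapiens), read by fluorescence and calcium flux, with a stated time of 15 min; on this read-out lower numbers stand for an effect already at smaller amounts and higher numbers for an effect only at larger amounts of compound. Compound 1 gives 1880 nM, the highest of the three numbers. Compound 2 gives 400 nM, a lower number than compound 1 by a margin beyond the scatter, and compound 3 gives 97 nM, lower still and furthest from compound 1. Compounds 2 and 3 each differ from compound 1 in more than one place, so neither gap can be tied to a single change.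

The step under consideration runs from compound 1 to compound 4, `CCN(Cc1cccnc1)C(=O)COc1ccc(C)cc1`. The change is pyridin-3-yl in place of phenyl on a saturated chain carbon bound to an amide-type nitrogen. Among the measured compounds shown here, no measured pair shows this change on its own, so there is nothing in the data that sets its size or direction. For the measured compounds named here, the one aromatic exchange that does appear, from benzyl to thiophen-2-ylmethyl, is entangled with other changes and cannot be read across. In this assay the step is expected to be modest, with the number for compound 4 likely staying close to or somewhat above that of compound 1, a 1.5-fold higher number from compound 1 to compound 4 (0.17 log units; within the scatter). Compound 4 is therefore estimated at 2800 nM, within a range from 900 nM to 9000 nM.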

Compound 4, half-maximal effective concentration: 15400 nM
The estimate for compound 4 lay 5.5-fold (0.74 log units) below the measured number; measured number above the stated range.
By their numbers in this assay, from the lowest: compound 3; then compound 2; then compound 1; then compound 4.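

In this assay, pyridin-3-yl in place of phenyl on a saturated chain carbon bound to an amide-type nitrogen comes with an 8.2-fold higher number from compound 1 to compound 4 (0.91 log units; beyond the scatter) and is the only step among these compounds that rests on a single change. It shows that this position is not indifferent to the aromatic ring it carries: pyridin-3-yl brings a ring nitrogen and a hydrogen-bond acceptor that phenyl lacks, and with the heavy-atom count unchanged the number still moves beyond the scatter and upward, which compound 1, compound 2 and compound 3 could not show, as they differ from one another in more than one place. No independent measurement is available to explain why this exchange raises the number.

The compounds shown leave open whether pyridin-2-yl or pyridin-4-yl on the same carbon would give a step of similar size and direction. They also leave open whether (pyridin-3-yl)methyl would keep this standing when set against the thiophen-2-ylmethyl group on an otherwise matched compound.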